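This account rests on a few compounds, and the source may have more. Where it says the series, first, only, none or still open, it means among the compounds named here.

Compound 1, `C[C@@]1(O)[C@@H](CO)OC(n2cnc3c(NC4CC4)ncnc32)[C@@H]1O`, and compound 2, `CNc1ncnc2c1ncn2C1O[C@H](CO)[C@@](C)(O)[C@H]1O`, share one core, while compound 3, `CNc1ncnc2c1ncn2C1O[C@H](CO)[C@@H](O)[C@@]1(C)O`, is built from the same atoms joined differently; the difference between the two cores is not broken down here. Compound 4, `C[C@]1(O)C(n2cnc3c(NC4CC4)ncnc32)O[C@H](CO)[C@H]1O`, stands on the core of compound 3 and has not yet been measured. In a functional assay on K562 cells (Homo sapiens) for inhibition (on this read-out lower numbers stand for stronger inhibition and higher numbers for weaker inhibition), compound 2 gives 43900 nM, and compound 1 gives 73000 nM. The change between them is cyclopropyl in place of methyl on a nitrogen on an aromatic ring, and it made a 1.7-fold higher number from compound 2 to compound 1 (0.22 log units; within the scatter). For compound 3 only a limit is reported in this assay, > 100000 nM, so compound 3 sits at the limit of > 100000 nM in this assay, at which 1 of the 3 values shown sits. The change from compound 3 to compound 4 is the same one, (cyclopropyl in place of methyl on a nitrogen on an aromatic ring), made on the other core. Resting on a 1.7-fold higher number from compound 2 to compound 1 (0.22 log units; within the scatter), compound 4 is expected to come out near 150000 nM, somewhere between 60000 nM and 400000 nM, which means an expected step that the limit leaves unreadable from compound 3 to compound 4. Since the starting point is itself a limit, the most likely outcome is that compound 4 again returns only a limit in this assay rather than a number.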

Compound 4, half-maximal inhibitory concentration: > 100000 nM
Compound 4 was reported as a limit; the forecaster's own chance of this, stated with the estimate: 80%; the middle value lies beyond the limit too.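

Compound 3 and compound 4 are both reported only as limits in this assay, so no step between them can be read: the limit of > 100000 nM in this assay, at which 2 of the 4 values shown sit.

The compounds shown leave open how far past that limit compound 3 and compound 4 lie, and whether methylamino to cyclopropylamino changes the read-out at all on their core.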